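The source may hold more compounds than are shown below. What is called first, only, known or untested is meant among the compounds shown, and "the series" means these compounds.

In a functional assay on L02 cells (Homo sapiens) for inhibition, read by Griess assay, with stated times of 1 h and 24 h (on this read-out higher numbers stand for weaker inhibition and lower numbers for stronger inhibition), compound 1 `C(=C/c1ccco1)\c1nc(NC2CC2)c2sccc2n1` gives > 1000000 nM, which is a limit of the assay and not a number. Compound 2 `Clc1ccc(CNc2nc(/C=C/c3ccco3)nc3ccsc23)cc1` also gives only a limit, > 1000000 nM. The evidence so far therefore amounts to the limit of > 1000000 nM in this assay, at which 2 of the 2 values shown sit, and compound 2 has no exact value from which to count. Compound 3 `Fc1ccc(CNc2nc(/C=C/c3ccco3)nc3ccsc23)cc1` differs from compound 2 in one place: fluoro in place of chloro on an aromatic carbon. This puts fluoro in place of chloro on an aromatic carbon, para to a large group. Among the measured compounds shown here, the only measured step is a step that the two limits leave unreadable from compound 1 to compound 2. It lies at a different place on the molecule and gives no size to carry over, so no shift beyond the scatter is expected in this assay. The expected change is a number no higher from compound 2 to compound 3 (the limit leaves the size open). For compound 3 the estimated value is 1000000 nM, within an expected range from 300000 nM to 2000000 nM.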

Compound 3, half-maximal inhibitory concentration: > 1000000 nM
Compound 3: no number, only a limit (the forecaster's own chance of this, stated with the estimate: 85%); the middle value lies on the limit itself.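

Compound 3 gives > 1000000 nM, which is a limit of the assay and not a number. Among the compounds shown here, with compound 1 and compound 2 also at limits, no step among the three can be read. The compounds shown leave open whether any group on the shared core gives an exact value in this assay.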